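Benzyl-ring halogenation in a triazole series: compound 3

The compounds below may be only part of what the source reports. "The series", "measured", "known", "first", "only" and "open" are said of these compounds alone.

compound 1 `Brc1cccc2c1nnn2Cc1ccccc1`: 80 nM
compound 2 `Fc1cccc(Cn2nnc3c(Br)cccc32)c1`: 18 nM

In a functional assay on cells for positive allosteric modulation of metabotropic glutamate receptor 2 (Homo sapiens), read by fluorescence and calcium flux, with a stated time of 30 min (a higher number here means that more compound is needed for the effect, a lower number that less compound is needed), compound 1 stands highest of the two numbers; the nearest is compound 2, reached by a 4.4-fold lower number from compound 1 to compound 2 (0.65 log units; beyond the scatter), fluoro in place of hydrogen on an aromatic carbon of the six-membered aromatic ring of carbon only. Compound 3 `Brc1ccc(Cn2nnc3c(Br)cccc32)cc1` differs from compound 1 by bromo in place of hydrogen on an aromatic carbon. For the measured compounds named here, only that one step bears on this change; it was modest and downward, and a halogen entering the same ring is again at hand, though the entering group is not the same. A downward step of similar or smaller size is therefore expected. Compound 3 is estimated at 40 nM, range 12 nM to 130 nM, an expected 2.0-fold lower number from compound 1 to compound 3 (0.30 log units; within the scatter).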

Compound 3, half-maximal effective concentration: 14 nM
For compound 3 the middle estimate is 2.9-fold (0.46 log units) above the measured one; the measured number falls inside the stated range.
By their numbers in this assay, from the lowest: compounds 3 and 2 (each within the scatter of the next); then compound 1.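

In this assay, bromo para to a large group also gives a 5.7-fold lower number from compound 1 to compound 3 (0.76 log units; beyond the scatter) and so joins fluoro as a second halogen that lowers the number on this ring. The gain at this ring therefore does not depend on fluoro alone. No evidence on hand accounts for the size of this step. Compounds 2 and 3 differ in more than one place, so the effects of the halogen and of its place on the ring remain unseparated. From the compounds shown here alone, whether a methoxy group, an amine or a carboxylic acid at the same carbon would also lower the number remains open.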